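From compound 3 to compound 4: a chloro step

The source may report more compounds than this note shows. Statements on the series, on what has been measured and on what is new or still open speak of the compounds shown alone.

In a functional assay on NCI-H460 cells (Homo sapiens) for inhibition, read by MTT assay, with a stated time of 24 h, tested at 10 ug/mL (a higher number here means more inhibition of growth at the concentration tested, a lower number less inhibition of growth), compound 1 `O=C(CCCCC(S)CCS)Nc1ccccc1` gives 8.37%, compound 2 `O=C(CCCCC(S)CCS)Nc1ccc(OC(F)(F)F)cc1` gives 29.2% and compound 3 `O=C(CCCCC(CCSC(=O)c1ccccc1)SC(=O)c1ccccc1)Nc1ccccc1` gives 11.4%. Compound 3 thus stands within the scatter of compound 1, and beyond the scatter from compound 2, which has the higher number.

Compound 4 `O=C(CCCCC(CCSC(=O)c1ccccc1)SC(=O)c1ccccc1)Nc1cccc(Cl)c1` has chloro in place of hydrogen on an aromatic carbon, meta to a large group, turning the phenylcarbamoyl into (3-chlorophenyl)carbamoyl: chloro in place of hydrogen on an aromatic carbon.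

Among the compounds with values here, only one measured step bears on this change: a number 20.8 percentage points higher from compound 1 to compound 2 (beyond the scatter). It involves trifluoromethoxy rather than chloro and starts from compound 1 rather than compound 3, so it offers a direction but only a loose guide to size. Within the data shown here, no chloro compound has been measured. A smaller upward step is therefore expected, and a result within the scatter remains possible. The expected change is a number 6.6 percentage points higher from compound 3 to compound 4 (within the scatter). Compound 4 is estimated at 18%, with an expected range from 7% to 34%.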

Compound 4, percent growth inhibition at one concentration: 9.12%
Beside the measured number, compound 4's estimate is 8.9 percentage points above it, and the stated range covers the measured number.
By their numbers in this assay, from the lowest: compounds 1, 4 and 3 (each within the scatter of the next); then compound 2.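

In this assay, chloro in place of hydrogen on an aromatic carbon, meta to a large group, gives a number 2.3 percentage points lower from compound 3 to compound 4 (within the scatter) and so leaves the reading on the core of compound 3 unchanged within the scatter. Within the data shown here, this is the first substituent step read on that core, and unlike a number 20.8 percentage points higher from compound 1 to compound 2 (beyond the scatter), which lies beyond the scatter, it gives no measurable gain; the two steps differ in both group and core, so neither difference can be singled out as the one that matters. No measured information on the compounds accounts for the chloro result.

Open, going by these compounds, is whether trifluoromethoxy keeps its step on the core of compound 3, and whether chloro would move the number on the core of compound 1. Also open, on these data alone, is how an amine or a carboxylic acid in place of that hydrogen would read.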